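This account rests on a few compounds, and the source may have more. Where it says the series, first, only, none or still open, it means among the compounds named here.

Two compounds of this series have been run in an ADME assay on the whole organism (plasma, strain Sprague-Dawley) for pharmacokinetics, with Rattus norvegicus as the target, read by LC-MS, at a dose of 25 mg/kg by the oral route; on this read-out higher numbers stand for higher exposure at the dose given and lower numbers for lower exposure. Compound 1 `C=CC(=O)N1CC[C@H](N2C(=O)N(Cc3ccccc3)Cc3cnc(Nc4ccc(N5CCN(C)CC5)cc4OC)nc32)C1` gives 418 ng.h/mL in this assay. Compound 2 `C=CC(=O)N1CC[C@H](N2C(=O)N(c3ccccc3)Cc3cnc(Nc4ccc(N5CCN(C)CC5)cc4)nc32)C1` gives 2310 ng.h/mL in this assay, the higher of the two numbers, with compound 1 as the nearer value at a gap well beyond the scatter. Going by the values given here, compound 1 and compound 2 differ in more than one place, so no single step between them can be read off; their two values show only that the higher exposure sits with compound 2.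

Compound 3 `C=CC(=O)N1CC[C@H](N2C(=O)N(c3ccccc3)Cc3cnc(Nc4ccc(N5CCN(C)CC5)cc4OC)nc32)C1` is yet to be measured in this assay. It is compound 2 with one change: methoxy in place of hydrogen on an aromatic carbon. Compound 1 also carries a methoxy, along with a second difference from compound 2, and in this assay compound 1 gives 418 ng.h/mL, the lower of the two measured numbers. Among the compounds with values here, no single-change pair is available to fix the size of the methoxy step. The step in this assay is expected to be a moderate fall, a 1.9-fold lower number from compound 2 to compound 3 (0.28 log units; within the scatter), with a result within the scatter of compound 2 not ruled out. Compound 3 is therefore estimated at 1200 ng.h/mL, within a range from 400 ng.h/mL to 3000 ng.h/mL.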

Compound 3, area under the concentration-time curve: 2130 ng.h/mL
Beside the measured number, compound 3's estimate is 1.8-fold (0.25 log units) below it; measured number inside the range.
By their numbers in this assay, from the lowest: compound 1; then compounds 3 and 2 (each within the scatter of the next).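

In this assay, methoxy in place of hydrogen on an aromatic carbon, ortho to a large group and meta to a 4-methylpiperazin-1-yl group, gives a 1.1-fold lower number from compound 2 to compound 3 (0.04 log units; within the scatter) and so leaves no difference that can be separated from the scatter when phenyl sits on the amide-type nitrogen. The other single change, phenyl in place of benzyl on that nitrogen in a ring, gives a 5.1-fold higher number from compound 1 to compound 3 (0.71 log units; beyond the scatter) with the methoxy held in place, so among these three compounds the difference in exposure tracks the nitrogen substituent and not the aromatic methoxy. Nothing at hand accounts for either step.

The compounds shown leave open whether methoxy would read the same way with benzyl on the nitrogen, and whether fluorine, an amine or a longer alkoxy chain at the same aromatic carbon would also stay within the scatter of compound 2. Also open, going by these compounds, is how this assay would respond to other nitrogen substituents, such as a pyridine ring or a short alkyl chain.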